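A few compounds are considered here, and "the series" means these few. Any claim that something is new, unique, unknown or untested is made for them only; others in the source may bear on it.

Among the compounds with values here, in an assay for binding affinity to dual specificity mitogen-activated protein kinase kinase 4 (Homo sapiens), read by KINOMEscan, tested at 100 nM (on this read-out higher numbers stand for a weaker effect at the one concentration tested and lower numbers for a stronger effect), compound 2 `CCCS(=O)(=O)Nc1ccc(F)c(C(=O)c2n[nH]c3ncc(-c4cccc(O)c4)cc23)c1F` gives 2.2%; the only other number is that of compound 1 `CCCS(=O)(=O)Nc1ccc(F)c(C(=O)c2n[nH]c3ncc(-c4ccccc4C)cc23)c1F`, which gives 7%, so the two values stand within the scatter of each other. Within the data shown here, the sole measured step, a number 4.8 percentage points lower from compound 1 to compound 2 (within the scatter), is the only guide available. Compound 3 `CCCS(=O)(=O)Nc1ccc(F)c(C(=O)c2n[nH]c3ncc(-c4ccc(N(C)C)cc4)cc23)c1F` brings (4-(dimethylamino)phenyl in place of 3-hydroxyphenyl on an aromatic carbon). Among the measured compounds shown here, no measured step covers this change directly, and the single step known stayed within the scatter, so in this assay a step beyond the scatter is expected in neither direction. Compound 3 is estimated at 5%, with a range from 1% to 20%, which corresponds to an expected step of a number 2.8 percentage points higher from compound 2 to compound 3 (within the scatter).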

Compound 3, a percentage reported as activity, at one concentration (the size of the read-out at that concentration, not a potency): 2.5%
Compound 3: the middle estimate sits 2.5 percentage points above what was measured; low and high end bracket the measured number.
By their numbers in this assay, from the lowest: compounds 2, 3 and 1 (each within the scatter of the next).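

In this assay, the step for 4-(dimethylamino)phenyl in place of 3-hydroxyphenyl is a number 0.3 percentage points higher from compound 2 to compound 3 (within the scatter), and the step for the same group in place of 2-methylphenyl is a number 4.5 percentage points lower from compound 1 to compound 3 (within the scatter). At this position, going from 1 hydrogen-bond donor to 0 and from 7 heavy atoms to 9 thus comes without a step beyond the scatter. Nothing available bears on why these numbers stay so close.

Still open, from the compounds shown here alone, is whether a carboxylic acid on the phenyl ring, or a morpholine replacing that ring, would give a step beyond the scatter.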